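Swapping an Aromatic Ring for a Short Ketone Chain

A few compounds are considered here, and "the series" means these few. Any claim that something is new, unique, unknown or untested is made for them only; others in the source may bear on it.

Of the compounds shown here, three with a shared core have been tested in a functional assay on the whole organism with Mus musculus as the target, in the maximal electroshock model, with a stated time of 0.5 h; a lower number here means that less compound is needed, a higher number that more compound is needed for the effect. Compound 1 `O=C(N/N=C/c1ccccc1Cl)Nc1ccc(Br)cc1` gives 300 mg/kg. Compound 2 `C/C(=N\NC(=O)Nc1ccc(Br)cc1)c1ccccc1` gives 100 mg/kg, and compound 3 `CCOc1ccc(NC(=O)N/N=C(\C)c2ccccc2O)cc1` gives 100 mg/kg. Compound 3 therefore stands level with compound 2 at the digits shown, the two together forming the lowest numbers of the set, while compound 1 sits clearly higher, beyond the usual scatter.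

Compound 4 `CCOc1ccc(NC(=O)N/N=C(\C)CC(C)=O)cc1` has not yet been measured. It differs from compound 3 in a single place: 2-oxopropyl in place of 2-hydroxyphenyl on a carbon with a double bond to nitrogen. In each of the three measured compounds, the carbon with a double bond to nitrogen carries an aromatic ring; compound 4 would be the first in which that ring is gone and a short chain stands in its place. Within the data shown here, no measured pair shows this kind of change, so its size cannot be read from the data. The expectation is that more compound will be needed, a step beyond the scatter. Compound 4 is expected to give 300 mg/kg, with a range from 100 mg/kg to 600 mg/kg. The expected step is a 3.0-fold higher number from compound 3 to compound 4 (0.48 log units; beyond the scatter).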

Compound 4, minimum effective dose: 100 mg/kg
Compound 4: middle estimate off by 3.0-fold (0.48 log units), on the high side; measured number inside the range.
By their numbers in this assay, from the lowest: compounds 2, 3 and 4 (each within the scatter of the next); then compound 1.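

In this assay the pair shows no change at the digits printed from compound 3 to compound 4 (within the scatter) and so, on this carbon with a double bond to nitrogen, the 2-hydroxyphenyl ring can give way to the ringless 2-oxopropyl chain without a step beyond the scatter. The earlier compounds shown here all carried an aromatic ring at this place, so they could not show whether a ring was needed there; with the rest of compound 3 kept, this pair shows that it is not. Nothing on hand explains why the two groups read alike.

From the compounds shown here alone, this is a single pair, so it stays open whether the same holds with the rest of compound 2 or compound 1 around it. Going by these compounds, it also stays open how a longer chain, an amine or a carboxylic acid would read at this place.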